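The source may report more compounds than this note shows. Statements on the series, on what has been measured and on what is new or still open speak of the compounds shown alone.

The measured compounds:

compound 1 `O=C(c1ccccc1)N1CCC(NS(=O)(=O)c2cc(S(=O)(=O)c3ccccc3)ccc2C(F)(F)F)CC1` — 70 nM
compound 2 `O=S(=O)(NC1CCN(S(=O)(=O)c2cccc(-c3nnn[nH]3)c2)CC1)c1cc(S(=O)(=O)c2ccccc2)ccc1C(F)(F)F` — 30 nM
compound 3 `CC(C)(C)OC(=O)N1CCC(CC(=O)N2CCC(NS(=O)(=O)c3cc(S(=O)(=O)c4ccccc4)ccc3C(F)(F)F)CC2)CC1` — 490 nM

In an assay on isolated protein for displacement of a labelled ligand from secreted frizzled-related protein 1 (Homo sapiens), read by fluorescence polarization, with a stated time of 30 min (a lower number here means a stronger inhibitor, a higher number a weaker inhibitor), compound 1 gives 70 nM, which places it second of the three numbers: compound 2 shows the lower value at 30 nM, and compound 3 the highest at 490 nM, both separated from compound 1 by more than the usual scatter. The unmeasured compound 4 `CC(C)(C)OC(=O)N1CC[C@H](C(=O)N2CCC(NS(=O)(=O)c3cc(S(=O)(=O)c4ccccc4)ccc3C(F)(F)F)CC2)C1` keeps the shared core of compound 1 and differs by 1-(tert-butoxycarbonyl)pyrrolidin-3-yl in place of phenyl on a carbonyl carbon. Since compound 3, which also carries a tert-butoxycarbonyl-bearing ring on that carbonyl carbon, gives 490 nM, a weakening step is expected, estimated as a 5.0-fold higher number from compound 1 to compound 4 (0.70 log units; beyond the scatter). Compound 4 is therefore expected to give about 350 nM in this assay, within a range from 120 nM to 1000 nM.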

Compound 4, half-maximal inhibitory concentration: 70 nM
The estimate for compound 4 lay 5.0-fold (0.70 log units) above the measured number, and the stated range ends above it.
By their numbers in this assay, from the lowest: compound 2; then compounds 1 and 4 (each within the scatter of the next); then compound 3.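

In this assay, 1-(tert-butoxycarbonyl)pyrrolidin-3-yl in place of phenyl on a carbonyl carbon gives no change at the digits printed from compound 1 to compound 4 (within the scatter), so at this position the aromatic ring of carbon only can be exchanged for this larger non-aromatic group with no change beyond the scatter. Within the data shown here, the earlier compounds offered no pair differing in one place, so this is the first direct reading of the position. Nothing measured here explains this result.

Still open, on these data alone, is whether the free pyrrolidin-3-yl amine, without its tert-butoxycarbonyl group, or a carboxylic acid on that carbonyl carbon would read alike. As far as these compounds go, the opposite configuration at the defined stereocentre also remains open.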